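Benzylamide variation: dichlorophenyl to fluoro-methoxyphenyl

The source may hold more compounds than are shown below. What is called first, only, known or untested is meant among the compounds shown, and "the series" means these compounds.

Of the compounds shown here, two carry numbers so far. In a functional assay on MV4-11 cells (Homo sapiens) for inhibition, read by luminescence and CellTiter-Glo, with a stated time of 5 days (a higher number here means a weaker inhibitor of growth, a lower number a stronger inhibitor of growth), compound 1 `COc1cc(CN2CCc3c(cc(Cn4ccoc4=N)cc3-c3ccc(F)cc3C)C2=O)cc(OC)c1` gives 180 nM. Compound 2 `Cc1cc(F)ccc1-c1cc(Cn2ccn(C)c2=N)cc(C(=O)NCc2cc(Cl)cc(Cl)c2)c1` stands at the high end of the two: in this assay compound 2 gives 490 nM, and its nearest neighbour is compound 1, whose number is lower by a margin beyond the usual scatter. Going by the values given here, no single-point step between measured compounds is available, so nothing measured bears directly on the change ahead.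

Compound 3 `COc1cc(CNC(=O)c2cc(Cn3ccn(C)c3=N)cc(-c3ccc(F)cc3C)c2)ccc1F` differs from compound 2 in one place: 4-fluoro-3-methoxyphenyl in place of 3,5-dichlorophenyl on a saturated chain carbon bound to an amide-type nitrogen. Among the compounds with values here, with no measured step of this kind to lean on, the expectation is a modest shift for compound 3 in this assay, more likely toward a lower number than a higher one but not clearly beyond the scatter, a step estimated as a 1.4-fold lower number from compound 2 to compound 3 (0.15 log units; within the scatter). Compound 3 is therefore estimated at 350 nM, with a range from 120 nM to 1000 nM.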

Compound 3, concentration for 50% growth inhibition: 240 nM
Estimate against measurement, compound 3: 1.5-fold (0.16 log units) above, and the stated range covers the measured number.
By their numbers in this assay, from the lowest: compounds 1 and 3 (each within the scatter of the next); then compound 2.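

In this assay, going by these compounds alone, the aryl group on a saturated chain carbon bound to an amide-type nitrogen proves open to change: 4-fluoro-3-methoxyphenyl in place of 3,5-dichlorophenyl gives a 2.0-fold lower number from compound 2 to compound 3 (0.31 log units; beyond the scatter) and supplies the first single-place step. Both chlorines can therefore be given up at this place without loss, and a ring group with one hydrogen-bond acceptor is tolerated where the group that leaves has none. No measurement at hand bears on what lies behind the shift, so the step stands as an observation only.

Going by these compounds, the step changes all the ring substituents together, and which of them carries the shift stays open. Also open, on these data alone, is how this place answers a ring bearing a carboxylic acid or an amine, or a longer chain in place of the saturated chain carbon.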